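The source may report more compounds than this note shows. Statements on the series, on what has been measured and on what is new or still open speak of the compounds shown alone.

Compound 1 `NC(=O)c1c(NC(=O)c2ccccc2Cl)sc2c1CCN(Cc1ccc(Cl)cc1)C2` stands at the weak end of the two compounds measured in a functional assay on MKN-74 cells (Homo sapiens) for antiproliferative activity, with a stated time of 24 h (on this read-out higher numbers stand for weaker inhibition and lower numbers for stronger inhibition), where compound 1 gives 18700 nM. Compound 2 `NC(=O)c1c(NC(=O)c2ccc(C(F)(F)F)cc2)sc2c1CCN(Cc1c(Cl)cccc1Cl)C2` gives 8530 nM in this assay, a lower number by a margin beyond the usual scatter. Compound 3 `CSc1ccccc1NC(=S)N1CCc2c(sc(NC(=O)c3ccccc3Cl)c2C(N)=O)C1` is not yet measured; it differs from compound 1 by a group of 11 heavy atoms (8 carbon, 1 nitrogen, 2 sulfur; one six-membered aromatic ring of carbon only) in place of a group of 8 heavy atoms (7 carbon, 1 chlorine; one six-membered aromatic ring of carbon only), on an amine nitrogen in a ring. Among the measured compounds shown here, no step of this kind has been measured among the compounds described here, so the direction of the change cannot be read from the data. The step of a 1.2-fold lower number from compound 1 to compound 3 (0.10 log units; within the scatter) is expected to be small, likely within the scatter. Compound 3 is therefore expected to give about 15000 nM in this assay, with a range of 5000 nM to 45000 nM.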

Compound 3, half-maximal inhibitory concentration: 13800 nM
Beside the measured number, compound 3's estimate is 1.1-fold (0.04 log units) above it; measured number inside the range.
By their numbers in this assay, from the lowest: compounds 2, 3 and 1 (each within the scatter of the next, the first and the last beyond it).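

Among the compounds shown here, this is the first step read at the amine nitrogen in the ring: in this assay, the group of 11 heavy atoms takes the place of 4-chlorobenzyl with a 1.4-fold lower number from compound 1 to compound 3 (0.13 log units; within the scatter). At this position, then, the exchange leaves the number within the scatter, even though the entering group brings a hydrogen-bond donor and acceptors that 4-chlorobenzyl lacks. Nothing measured here accounts for this result. Going by these compounds, whether a longer alkyl chain or a carboxylic acid on this nitrogen would move the number beyond the scatter remains open.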